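Metabolic stability of a neopentyl-to-hexyl swap on a guanidine

The source may hold more compounds than are shown below. What is called first, only, known or untested is meant among the compounds shown, and "the series" means these compounds.

Compound 1, `CON/C(=N\C1=NC(=O)C(=O)N1C(C)C)Nc1ccc(Cl)c(Cl)c1`. In an in vitro ADME assay on microsomes from liver (Mus musculus) for metabolic stability, read by LC-MS (on this read-out higher numbers stand for a longer-lived compound and lower numbers for a shorter-lived compound), compound 1 gives > 1 h, which is a limit of the assay and not a number.
Compound 2, `CCON/C(=N\C1=NC(=O)C(=O)N1C(C)C)Nc1ccc(Cl)c(Cl)c1`. In this assay compound 2 gives > 1 h, again a limit.
Compound 3, `CC(C)N1C(=O)C(=O)N=C1/N=C(\NCC(C)(C)C)Nc1ccc(Cl)c(Cl)c1`. In this assay compound 3 gives > 1 h, also a limit.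

All three measured compounds sit at the limit of > 1 h in this assay, at which 3 of the 3 values shown sit, so none of the steps between them can be sized: a step that the two limits leave unreadable from compound 1 to compound 2, a step that the two limits leave unreadable from compound 1 to compound 3 and a step that the two limits leave unreadable from compound 2 to compound 3 are each left unreadable. Compound 3 therefore stands no lower than its limit, with nothing to separate it from compound 1 or compound 2.

Compound 4, `CCCCCCN/C(=N\C1=NC(=O)C(=O)N1C(C)C)Nc1ccc(Cl)c(Cl)c1`, differs from compound 3 by pentyl in place of tert-butyl on a saturated chain carbon bound to an amine nitrogen. Going by the values given here, no measured step bears on this change beyond the limits just described, and because every measured compound rests at the limit of > 1 h in this assay, at which 3 of the 3 values shown sit, no direction can be read for compound 4. The step from compound 3 to compound 4 in this assay is therefore expected to be small or invisible, a step that the limit leaves unreadable from compound 3 to compound 4. For compound 4 a half-life of about 1.2 h is estimated, in the range 0.5 h to 3 h, most likely reported again only as a limit.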

Compound 4, half-life: 0.579 h
The estimate for compound 4 lay 2.1-fold (0.32 log units) above the measured number, within the range that was stated.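

Going by these compounds alone, compound 4 is the first compound here whose half-life falls inside the measurable range of this assay, so the group on this amine nitrogen can move the read-out, which the earlier compounds could not show. Going to hexyl reads as an at least 1.7-fold lower number from compound 3 to compound 4 (0.23 log units; that floor lies within the scatter), and the same comparison with the two oxygen-linked groups reads as an at least 1.7-fold lower number from compound 2 to compound 4 (0.23 log units; that floor lies within the scatter) and an at least 1.7-fold lower number from compound 1 to compound 4 (0.23 log units; that floor lies within the scatter). These figures are floors and not true sizes, because the other three compounds rest at a limit: the limit of > 1 h in this assay, at which 3 of the 4 values shown sit.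

On these data alone, how far those three lie beyond their limit stays unknown, so the real size of each step remains open. As far as these compounds go, whether chain length or the loss of branching matters more also remains open, and a straight butyl chain beside a branched hexyl chain would help separate the two.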